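The source may hold more compounds than are shown below. What is called first, only, known or untested is meant among the compounds shown, and "the series" means these compounds.

Compound 2 `Cc1nc(N)sc1CCCN/C(N)=N/C(=O)NC(c1ccccc1)c1ccccc1` gives 43.7 nM in an assay on membranes from Sf9 cells for displacement of a labelled ligand from histamine H2 receptor (Homo sapiens), read by scintillation counting, with a stated time of 60 min; a lower number here means a stronger inhibitor, a higher number a weaker inhibitor. Compound 1 `Cc1nc(N)sc1CCCN/C(N)=N/C(=O)NC(c1ccccc1)C(C)C` gives 35.5 nM, and compound 3 `CCCCCCNC(=O)/N=C(\N)NCCCc1sc(N)nc1C` gives 28.8 nM; all three numbers lie within the usual scatter of one another. Compound 4 `CCC(NC(=O)/N=C(\N)NCCCc1sc(N)nc1C)c1ccccc1` has not yet been measured; its change from compound 2 is ethyl in place of phenyl on a saturated chain carbon bound to an amide-type nitrogen and an aromatic carbon. Among the measured compounds shown here, the only measured step at this same place, a 1.2-fold higher number from compound 1 to compound 2 (0.09 log units; within the scatter), shows that swapping one group for another there barely moved the number. Because a 1.2-fold higher number from compound 1 to compound 2 (0.09 log units; within the scatter) was so small, the step from compound 2 to compound 4 is expected to be a 1.2-fold lower number from compound 2 to compound 4 (0.08 log units; within the scatter), with no change beyond the scatter. Compound 4 is therefore estimated at 36 nM, with a range of 15 nM to 85 nM.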

Compound 4, inhibition constant: 63.1 nM
The estimate for compound 4 lay 1.8-fold (0.24 log units) below the measured number; the measured number falls inside the stated range.
By their numbers in this assay, from the lowest: compounds 3, 1, 2 and 4 (each within the scatter of the next, the first and the last beyond it).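

Ethyl in place of phenyl gives a 1.4-fold higher number from compound 2 to compound 4 (0.16 log units; within the scatter), so on this saturated chain carbon the aromatic ring can be lost without a change beyond the scatter. Hydrogen in place of methyl, which turns the isopropyl of compound 1 into the ethyl of compound 4, gives a 1.8-fold higher number from compound 1 to compound 4 (0.25 log units; within the scatter), so this smaller trim also stays within the scatter. Phenyl, isopropyl and ethyl at this place therefore cannot be told apart in this binding measurement.

No evidence here explains this result. Going by these compounds, whether an amine, a carboxylic acid or a longer chain at this place would keep the number in this range remains open.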